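The source may hold more compounds than are shown below. What is called first, only, known or untested is meant among the compounds shown, and "the series" means these compounds.

Measured in an assay on isolated protein for inhibition of Indoleamine 2,3-dioxygenase 1 (Homo sapiens); a lower number here means a stronger inhibitor, a higher number a weaker inhibitor:

compound 1 `OCc1cn(CCNc2nonc2/C(=N/O)Nc2ccc(F)c(Br)c2)nn1` — 77 nM
compound 2 `OCCCc1cn(CCNc2nonc2/C(=N/O)Nc2ccc(F)c(Br)c2)nn1` — 98 nM
compound 3 `CCC(O)c1cn(CCNc2nonc2/C(=N/O)Nc2ccc(F)c(Br)c2)nn1` — 73 nM

Compound 3 gives the lowest of the three numbers, but neither neighbour is separated from it beyond the scatter: the step of a 1.1-fold lower number from compound 1 to compound 3 (0.02 log units; within the scatter) and the step of a 1.3-fold lower number from compound 2 to compound 3 (0.13 log units; within the scatter) both fall inside it, as does a 1.3-fold higher number from compound 1 to compound 2 (0.10 log units; within the scatter). Across the three, variation of the hydroxyalkyl group on the aromatic carbon of the shared core has left this assay essentially unchanged.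

Compound 4 `O/N=C(\Nc1ccc(F)c(Br)c1)c1nonc1NCCn1cc(C2(O)CCCCC2)nn1` takes the same position one step further: 1-hydroxycyclohexyl in place of 1-hydroxypropyl on an aromatic carbon. Among the compounds with values here, no measured pair shows a ring entering at this position, so the step has no direct precedent. The three steps that bear on it, all of them within the scatter, concern the length and branching of the hydroxyalkyl group on that carbon and show this assay tolerant of such changes. The nearest analogue is compound 3, where an ethyl already sits on the carbinol carbon.

The expectation is therefore no step beyond the scatter, estimated as a 1.1-fold higher number from compound 3 to compound 4 (0.04 log units; within the scatter), with a wider range than usual because a ring is a larger change than any measured here. For compound 4 the estimate in this assay is 80 nM, between 35 nM and 180 nM.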

Compound 4, half-maximal inhibitory concentration: 62 nM
Compound 4: the middle estimate sits 1.3-fold (0.11 log units) above what was measured, within the range that was stated.
By their numbers in this assay, from the lowest: compounds 4, 3, 1 and 2 (each within the scatter of the next).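

In this assay, within the data shown here, a six-membered non-aromatic ring of carbon only enters at the aromatic carbon of the five-membered aromatic ring with 3 nitrogen, and no step from the three earlier compounds leaves the scatter (a 1.2-fold lower number from compound 3 to compound 4 (0.07 log units; within the scatter); a 1.2-fold lower number from compound 1 to compound 4 (0.09 log units; within the scatter); a 1.6-fold lower number from compound 2 to compound 4 (0.20 log units; within the scatter)). The tolerance earlier seen only for the length and branching of open hydroxyalkyl chains therefore extends, within these four compounds, to 1-hydroxycyclohexyl, and the step from the 3-hydroxypropyl of compound 2 also stays within the scatter. No supporting measurement is available to explain this flat response.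

From the compounds shown here alone, all four compounds keep a hydroxy group on the side chain, so it remains open whether this assay stays as flat with plain cyclohexyl, or with an amine or a carboxylic acid in place of that hydroxy group. Also open, going by these compounds, is how this position responds to a phenyl ring or a piperidine ring, whose entry would show whether the tolerance reaches beyond a non-aromatic ring of carbon only.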